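Saturated-ring substituent swaps in the piperidine-bearing series

This account rests on a few compounds, and the source may have more. Where it says the series, first, only, none or still open, it means among the compounds named here.

Compound 3 `CCCCCOC(=O)N1CCN(C(=O)[C@H](CCC(=O)O)NC(=O)c2cc(N3CCC(OCCO)CC3)nc(-c3ccccc3)n2)CC1` gives 0.00833 h in an in vivo ADME assay on the whole organism (strain Sprague-Dawley) for metabolic stability, with Rattus norvegicus as the target; a lower number here means that the compound disappears faster, a higher number that the compound lasts longer. Compound 1 `CCCCCOC(=O)N1CCN(C(=O)[C@H](CCC(=O)O)NC(=O)c2cc(N3CCC(C(=O)N(CC)CC)CC3)nc(-c3ccccc3)n2)CC1` gives 0.00667 h and compound 2 `CCCCCOC(=O)N1CCN(C(=O)[C@H](CCC(=O)O)NC(=O)c2cc(N3CCC(C(=O)NCC)CC3)nc(-c3ccccc3)n2)CC1` gives 0.005 h in this assay; the steps of a 1.2-fold higher number from compound 1 to compound 3 (0.10 log units; within the scatter) and a 1.7-fold higher number from compound 2 to compound 3 (0.22 log units; within the scatter) both stay within the scatter, so the three numbers cannot be ordered. Compound 4 `CCCCCOC(=O)N1CCN(C(=O)[C@H](CCC(=O)O)NC(=O)c2cc(N3CCC(COC)CC3)nc(-c3ccccc3)n2)CC1` differs from compound 3 by methoxymethyl in place of 2-hydroxyethoxy on a saturated ring carbon. Among the measured compounds shown here, the steps that bear on it are those at the same saturated ring carbon, a 1.2-fold higher number from compound 1 to compound 3 (0.10 log units; within the scatter) and a 1.7-fold higher number from compound 2 to compound 3 (0.22 log units; within the scatter), neither of which moved the number beyond the scatter. The expected step of a 1.0-fold lower number from compound 3 to compound 4 (0.02 log units; within the scatter) in this assay is therefore none beyond the scatter. Compound 4 is estimated at 0.008 h, with a range of 0.004 h to 0.016 h.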

Compound 4, half-life: 0.015 h
Compound 4: the middle estimate sits 1.9-fold (0.27 log units) below what was measured, within the range that was stated.
By their numbers in this assay, from the lowest: compounds 2, 1, 3 and 4 (each within the scatter of the next, the first and the last beyond it).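

Among the compounds shown here, at this saturated ring carbon, methoxymethyl is the first group to separate from the two carbamoyl groups in this assay: a 3.0-fold higher number from compound 2 to compound 4 (0.48 log units; beyond the scatter) and a 2.2-fold higher number from compound 1 to compound 4 (0.35 log units; beyond the scatter) both lie beyond the scatter, though both are modest. Against 2-hydroxyethoxy, a 1.8-fold higher number from compound 3 to compound 4 (0.26 log units; within the scatter) stays within the scatter, so those two groups cannot be ordered. Nothing measured here offers an explanation for these steps.

As far as these compounds go, how an amine, a carboxylic acid or a longer chain at this carbon would read remains open. Also open, from the compounds shown here alone, is whether the methoxymethyl step holds when another part of the shared core changes.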